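The source may hold more compounds than are shown below. What is called first, only, known or untested is meant among the compounds shown, and "the series" means these compounds.

Working notes on the series. Within the data shown here, in a functional assay on ileum (Cavia porcellus) for antagonist activity (a lower number here means a stronger inhibitor, a higher number a weaker inhibitor), compound 3 (`CCc1ccccc1OCC(O)COc1ccc2c(O)c([N+](=O)[O-])c(=O)oc2c1`) gives 2700 nM, the higher of the two actual numbers so far. Compound 1 (`Cc1ccccc1OCCCOc1ccc2c(O)c([N+](=O)[O-])c(=O)oc2c1`) gives 590 nM, a lower number by more than the scatter. Compound 2 (`O=C(O)c1ccc(OCC(O)COc2ccc3c(O)c([N+](=O)[O-])c(=O)oc3c2)cc1`) returns only a limit, > 10000 nM.

Compound 4 (`CCCc1ccccc1OCC(O)COc1ccc2c(O)c([N+](=O)[O-])c(=O)oc2c1`) has methyl in place of hydrogen on a saturated chain carbon, two bonds along the chain from an aromatic carbon, so that 2-ethylphenyl becomes 2-propylphenyl: methyl in place of hydrogen on a saturated chain carbon, two bonds along the chain from an aromatic carbon.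

Among the measured compounds shown here, one measured step touches this part of the structure: an at least 3.7-fold lower number from compound 2 to compound 3 (0.56 log units; beyond the scatter). That step exchanges 4-carboxyphenyl for 2-ethylphenyl, and its size is only a bound, since one end of it is a limit. For the measured compounds named here, it is a far larger exchange than a single added methyl, and no measured step lengthens ethyl to propyl, so its size does not carry over. With only the value of compound 3 at 2700 nM as an anchor, no shift beyond the scatter is expected in this assay. The expected change is small, estimated as a 1.1-fold lower number from compound 3 to compound 4 (0.05 log units; within the scatter). For compound 4 the estimated value is 2400 nM, with an expected range of 800 nM to 7000 nM.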

Compound 4, half-maximal inhibitory concentration: 110 nM
Compound 4: the middle estimate sits 22-fold (1.34 log units) above what was measured; measured number outside the range, below it.
By their numbers in this assay, from the lowest: compound 4; then compound 1; then compound 3. At a limit, above all of these: compound 2.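

In this assay, the single methyl that turns 2-ethylphenyl into 2-propylphenyl is a large change on its own: a 25-fold lower number from compound 3 to compound 4 (1.39 log units; beyond the scatter). Among these compounds, the only step at this part of the structure before this one exchanged a whole substituted phenyl group, so this is the first sign that one added carbon at this saturated chain carbon, two bonds along the chain from an aromatic carbon, can move the number well beyond the scatter. The wider exchange of 4-carboxyphenyl for 2-propylphenyl now reads as an at least 90-fold lower number from compound 2 to compound 4 (1.95 log units; beyond the scatter), and its size is only a bound, as compound 2 stands at a limit: the limit of > 10000 nM in this assay, at which 1 of the 4 values shown sits.

Ethyl to propyl is a single step in chain length, which gives two points and no trend, so it remains open whether a longer chain such as butyl would extend the drop in this assay or reverse it. Also open, as far as these compounds go, is whether the gain depends on a straight chain, which isopropyl would test, and whether an amine or a hydroxyl group on the propyl chain would keep it.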